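Methoxy for fluoro: expected clearance of compound 3

The compounds below may be only part of what the source reports. "The series", "measured", "known", "first", "only" and "open" are said of these compounds alone.

The series has one measured anchor in an in vitro ADME assay on microsomes from liver (Homo sapiens) for metabolic stability; on this read-out lower numbers stand for slow clearance and higher numbers for fast clearance: compound 1 `c1ccc(C2CCc3nc[nH]c3C2)cc1` gives 7 mL.min-1.g-1. Compound 2 `Fc1ccccc1C1Cc2nccn2C1` has no number to set beside it, since the entry for compound 2 reads "not determined" (no result reported). Its standing on this read-out is therefore open, and it offers no measured starting point for the next structure.

That structure is compound 3 `COc1ccccc1C1Cc2nccn2C1`. The change is methoxy in place of fluoro on an aromatic carbon. Among the measured compounds shown here, no measured step in this assay covers this change, so any size remains an expectation: a modest move toward higher clearance, with compound 1 at 7 mL.min-1.g-1 as the only guide to the level. For compound 3 the estimated intrinsic clearance is 12 mL.min-1.g-1, with an expected range of 4 mL.min-1.g-1 to 35 mL.min-1.g-1.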

Compound 3, intrinsic clearance in microsomes: 37 mL.min-1.g-1
For compound 3 the middle estimate is 3.1-fold (0.49 log units) below the measured one; measured number above the stated range.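

Among the compounds shown here, compound 2 has no single number in this assay, and no step to compound 3 can be read from it. Going by these compounds, the size of the change from fluoro to methoxy on this read-out stays open. No measured evidence at hand bears on the result for compound 3.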